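Indolyl in Place of Chlorophenyl on the Shared Core

This account rests on a few compounds, and the source may have more. Where it says the series, first, only, none or still open, it means among the compounds named here.

Among the measured compounds shown here, in a functional assay on A549 cells (Homo sapiens) for inhibition, read by CCK-8 assay, with a stated time of 48 h (on this read-out higher numbers stand for weaker inhibition and lower numbers for stronger inhibition), compound 1 `COc1cc(-c2ccnc3cc(-c4ccc(Cl)cc4)nn23)cc(OC)c1OC` gives 3070 nM, the only true number among the three measured compounds. Compound 2 `COc1cc(-c2ccnc3c(-c4ccc(C)cc4)cnn23)cc(OC)c1OC` reaches only a limit, > 10000 nM. Compound 3 `COc1cc(-c2cc3nccc(-c4c[nH]c5ccccc45)n3n2)cc(OC)c1OC` likewise reaches only a limit, > 10000 nM. Two of the three values therefore sit at the limit of > 10000 nM in this assay, at which 2 of the 3 values shown sit. Compound 4 `COc1cc(-c2ccnc3cc(-c4c[nH]c5ccccc45)nn23)cc(OC)c1OC` has not yet been measured; it differs from compound 1 in a single place (1H-indol-3-yl in place of 4-chlorophenyl on an aromatic carbon). For the measured compounds named here, no step between measured compounds exists here, so the size of this change can only be estimated. Because compound 3, which bears the same entering group on a different arrangement of the shared core, sits at the limit of > 10000 nM in this assay, at which 2 of the 3 values shown sit, a step toward weaker inhibition seems more likely than one toward stronger. Compound 4 is expected to give about 8000 nM, with a range from 2500 nM to 25000 nM. The expected step of a 2.6-fold higher number from compound 1 to compound 4 (0.42 log units; beyond the scatter) would exceed the usual scatter, with a fair chance that only a limit is reported.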

Compound 4, half-maximal inhibitory concentration: 29 nM
For compound 4 the middle estimate is 280-fold (2.44 log units) above the measured one, and the stated range ends above it.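

The group on this aromatic carbon has a strong hold on inhibition: in this assay, 1H-indol-3-yl in place of 4-chlorophenyl brings a 110-fold lower number from compound 1 to compound 4 (2.02 log units; beyond the scatter). The earlier compounds shown here, with no step among them, could not show how much this position can matter. Nothing shown accounts for the size of this step.

The compounds shown leave open whether the hydrogen on the indole nitrogen is needed, which a 1-methylindol-3-yl group would test. They also leave open whether other fused rings, such as a benzofuran-3-yl group, would serve here.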